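Tetrazole for carboxylic acid on a weakly active series

The source may hold more compounds than are shown below. What is called first, only, known or untested is meant among the compounds shown, and "the series" means these compounds.

Measured compounds:
compound 1 `O=C(O)c1ccc(COc2ccc(CN3C(=O)CC[C@H]3C(=O)NCc3ccccc3)cc2)cc1`: > 5000 nM
compound 2 `O=C(NCc1ccccc1)[C@@H]1CCC(=O)N1Cc1ccc(OCc2ccc(-c3nn[nH]n3)cc2)cc1`: > 5000 nM
compound 3 `O=C(O)c1ccc(COc2ccc(CNC(=O)[C@@H]3CCCN3Cc3ccccc3)cc2)cc1`: > 5000 nM

In an assay on HEK293 cells for inhibition of Ataxin-2 (Mus musculus), read by fluorescence and Amplex Red (a higher number here means a weaker inhibitor, a lower number a stronger inhibitor), compound 1 gives only a limit, > 5000 nM. Compound 2, made by the change (2H-tetrazol-5-yl in place of carboxy on an aromatic carbon), also gives only a limit in this assay, > 5000 nM. The step that the two limits leave unreadable from compound 1 to compound 2 therefore cannot be read. Compound 3 carries a different core, and how it differs from the core of compound 1 is not broken down here. In this assay compound 3 gives a limit as well, > 5000 nM. Compound 4 `O=C(NCc1ccc(OCc2ccc(-c3nn[nH]n3)cc2)cc1)[C@@H]1CCCN1Cc1ccccc1` is the not yet measured partner of compound 3, arising from the same change, (2H-tetrazol-5-yl in place of carboxy on an aromatic carbon). Since the limit of > 5000 nM in this assay, at which 3 of the 3 values shown sit, shows every value at the limit, compound 4 is expected to stay there too, with an expected step that the limit leaves unreadable from compound 3 to compound 4. The estimate for compound 4 is 8000 nM, between 3000 nM and 30000 nM.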

Compound 4, half-maximal inhibitory concentration: > 5000 nM
Compound 4: no number, only a limit; the forecaster's own chance of this, stated with the estimate: 85%; the middle value is on the limit's open side.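

Compound 3 and compound 4 each give only a limit, not a number, so the step between them cannot be read. The compounds shown leave open whether swapping carboxy for 2H-tetrazol-5-yl changes inhibition at all.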